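This account rests on a few compounds, and the source may have more. Where it says the series, first, only, none or still open, it means among the compounds named here.

Of the compounds shown here, three of a shared core have been measured in an assay on HEK293 cells for inhibition of Voltage-dependent T-type calcium channel subunit alpha-1G (Homo sapiens), read by patch clamp; on this read-out lower numbers stand for stronger inhibition and higher numbers for weaker inhibition. Compound 1 `CCCc1nc(-c2ccccc2)c(CNCCN2CCN(c3ccc(F)cc3)CC2)o1` gives 7080 nM in this assay. Compound 2 `CCCc1nc(-c2ccccc2)c(CNCCCN2CCN(c3ccccc3Cl)CC2)o1` gives 2800 nM, and compound 3 `CCCc1nc(-c2ccccc2)c(CNCCN2CCN(C(c3ccccc3)c3ccccc3)CC2)o1` gives 7470 nM. Compound 1 thus stands second highest of the three numbers: its number and that of compound 3 lie within the scatter of each other, while compound 2 gives a number that sits beyond the scatter below it.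

Compound 4 `CCCc1nc(-c2ccccc2)c(CNCCN2CCN(c3cccc(C)c3C)CC2)o1` has not yet been measured in this assay. It differs from compound 1 in one place: 2,3-dimethylphenyl in place of 4-fluorophenyl on an amine nitrogen in a ring. Among the measured compounds shown here, no measured pair in this set shows that same change, so the size of the step has to be judged from the spread of the three numbers, which all fall within a modest range.

Compound 4 is expected to give a number close to that of compound 1, with a step of a 1.6-fold lower number from compound 1 to compound 4 (0.20 log units; within the scatter) that is estimated to lie within or only just beyond the scatter. The expected value for compound 4 is 4500 nM, with a range from 1500 nM to 13000 nM.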

Compound 4, half-maximal inhibitory concentration: 1710 nM
The estimate for compound 4 lay 2.6-fold (0.42 log units) above the measured number; low and high end bracket the measured number.
By their numbers in this assay, from the lowest: compounds 4 and 2 (each within the scatter of the next); then compounds 1 and 3 (each within the scatter of the next).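

In this assay, the place on the amine nitrogen in a ring proves able to move the number: 2,3-dimethylphenyl in place of 4-fluorophenyl gives a 4.1-fold lower number from compound 1 to compound 4 (0.62 log units; beyond the scatter) and so lies beyond the scatter, though the step is modest in size. Among the compounds shown here, this is the only pair in the set that differs in one place, so it gives the only direct reading of any change on this core. Nothing available explains why the number falls with this change.

The change removes the fluorine and brings in two methyl groups at once, so the compounds shown cannot separate these parts. As far as these compounds go, whether a plain phenyl group or a phenyl group with a single methyl would give a similar step stays open, as does whether the step holds with a longer chain, as in compound 2.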